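The source may report more compounds than this note shows. Statements on the series, on what has been measured and on what is new or still open speak of the compounds shown alone.

Measured so far in a functional assay on A549 cells (Homo sapiens) for cytotoxicity, read by colorimetric assay and MTT assay, with a stated time of 3 days, tested at 1 uM; a higher number here means a weaker effect of the compound at the concentration tested, a lower number a stronger effect:

compound 1 `COc1ccc(-c2nc(-c3ccccc3)c(-c3ccc4c(c3)NC(=O)CO4)[nH]2)cc1`: 101%
compound 2 `O=C1COc2ccc(-c3nn(-c4ccc(Br)cc4)cc3-c3ccccc3)cc2N1`: 81.5%
compound 3 `O=C1COc2ccc(-c3[nH]c(-c4c[nH]c5ncccc45)nc3-c3ccccc3)cc2N1`: 100%

Compound 2 stands lowest of the three numbers in this assay. Compound 3 is the nearest to it and compound 1 the furthest; both gaps lie beyond the scatter. Compound 1 and compound 3 differ from each other by a number 1 percentage points lower from compound 1 to compound 3 (within the scatter), a step that concerns a different place on the shared core and is within the scatter.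

Compound 4 `O=C1COc2ccc(-c3nn(-c4ccccc4)cc3-c3ccccc3)cc2N1` is to be measured in this assay. It differs from compound 2 by hydrogen in place of bromo on an aromatic carbon.

For the measured compounds named here, no measured step bears on this change: the only step recorded, between compound 1 and compound 3, swaps a larger group at another position and tells nothing about bromo against hydrogen. Going by the values given here, the single pair that gives any footing, compound 2 against the other two, shows that the only number clearly below the others carries the bromo. Among the compounds with values here, with no direct precedent, the step from compound 2 to compound 4 is expected to be small, in the direction of a weaker effect, and possibly within the scatter. The step expected is a number 8.5 percentage points higher from compound 2 to compound 4 (within the scatter). Compound 4 is therefore estimated at 90%, in the range 75% to 102%.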

Compound 4, a percentage reported as activity, at one concentration (the size of the read-out at that concentration, not a potency): 92.2%
Compound 4: the middle estimate sits 2.2 percentage points below what was measured; the measured number falls inside the stated range.
By their numbers in this assay, from the lowest: compound 2; then compounds 4, 3 and 1 (each within the scatter of the next).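

In this assay, for the compounds shown here, the change from 4-bromophenyl to phenyl gives the first direct reading at this position: the step is a number 10.7 percentage points higher from compound 2 to compound 4 (beyond the scatter) and shows that, on this core, hydrogen in place of bromo weakens the effect at the concentration tested. The difference is therefore tied to a single atom on an aromatic carbon, para to a large group, and compound 2 keeps the stronger effect of this pair. The step is modest and rests on one pair, so it gives no rule for the series, and nothing shown gives a reason for it.

As far as these compounds go, it remains open whether another group at the same place, such as chloro, methoxy, an amine or a carboxylic acid, would match bromo, go beyond it or behave like hydrogen. From the compounds shown here alone, it also remains open whether bromo would lower the number in the same way on the cores of compound 1 and compound 3, or whether the step belongs to the core shared by compound 2 and compound 4 alone.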